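A shorter side chain on compound 2

This account rests on a few compounds, and the source may have more. Where it says the series, first, only, none or still open, it means among the compounds named here.

- compound 1 `Cc1c(-c2ccc(O)cc2)n(CCCCOc2ccccc2)c2ccccc12` gives 3100 nM as its measured value
- compound 2 `Cc1c(-c2ccc(O)cc2)n(CCCCOc2ccccc2)c2ccc(O)cc12` gives 2000 nM as its measured value

Among the measured compounds shown here, both values come from a functional assay on A2780 cells (Homo sapiens) for inhibition, read by trypan blue exclusion, with a stated time of 72 h (on this read-out lower numbers stand for stronger inhibition of growth and higher numbers for weaker inhibition of growth), and are the only numbers available so far. For the measured compounds named here, the one measured step (a 1.6-fold lower number from compound 1 to compound 2 (0.19 log units; within the scatter)) leaves compound 2 level with compound 1, its only neighbour.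

Compound 3 `Cc1c(-c2ccc(O)cc2)n(CCCOc2ccccc2)c2ccc(O)cc12` keeps the core of compound 2 but alters the chain, with phenoxy in place of phenoxymethyl on a saturated chain carbon, three bonds along the chain from an aromatic nitrogen. Going by the values given here, the measured step concerns a hydroxy group on an aromatic carbon, so no measurement yet shows what this chain change does. With no evidence for a shift in either direction, none beyond the scatter is expected in this assay for this change. The expected result is a 1.2-fold higher number from compound 2 to compound 3 (0.08 log units; within the scatter) on this evidence. Compound 3 is estimated at 2400 nM with an expected range from 900 nM to 6000 nM in this test.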

Compound 3, concentration for 50% growth inhibition: 2200 nM
Compound 3: middle estimate off by 1.1-fold (0.04 log units), on the high side; low and high end bracket the measured number.
By their numbers in this assay, from the lowest: compounds 2, 3 and 1 (each within the scatter of the next).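

Trimming phenoxymethyl to phenoxy on a saturated chain carbon, three bonds along the chain from an aromatic nitrogen, gives the first reading on the side chain rather than on the core: in this assay the change amounts to a 1.1-fold higher number from compound 2 to compound 3 (0.04 log units; within the scatter). At this place, then, the shorter chain keeps growth inhibition level with the longer one, and the shared core and its hydroxy groups stay as they were. No measurement in hand bears on why the number holds steady under this change.

As far as these compounds go, it remains open whether a longer chain, or one shorter still, would also leave the number level. From the compounds shown here alone, it is equally open what would happen if an amine such as piperidine stood at the chain end in place of the phenoxy group.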